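The source may hold more compounds than are shown below. What is called first, only, known or untested is meant among the compounds shown, and "the series" means these compounds.

Measured so far:
- Compound 1, `CCC1C(=O)N(C)c2cnc(-n3ccc4cc(C(=O)NCC(C)C)ccc43)nc2N1c1ccn(C)n1`: 4970 nM
- Compound 2, `CCCNS(=O)(=O)c1ccc(Nc2ncc3c(n2)N(c2ccn(C)n2)C(CC)C(=O)N3C)cc1`: 2670 nM
- Compound 3, `CCCNC(=O)c1ccc2c(ccn2-c2ncc3c(n2)N(C2CCCC2)[C@H](CC)C(=O)N3C)c1`: 238 nM

Of the compounds shown here, three have been tested in a functional assay on HeLa cells (Homo sapiens) for antiproliferative activity, read by CCK-8 assay, with a stated time of 72 h; on this read-out higher numbers stand for weaker inhibition of growth and lower numbers for stronger inhibition of growth. Among them compound 1 gives the highest number, 4970 nM. The nearest neighbour on this scale is compound 2, whose value of 2670 nM lies within the scatter of repeated measurements, so the two cannot be told apart. Among the measured compounds shown here, compound 3, at 238 nM, sits well beyond the scatter from compound 1 and is the clearly stronger inhibitor of growth of the three; it differs from compound 1 in more than one place, so no single step can be drawn between them.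

The compound now in question is compound 4, `CCC1C(=O)N(C)c2cnc(-n3ccc4cc(C(=O)NC5CCCC5)ccc43)nc2N1c1ccn(C)n1`. It differs from compound 1 in one place only: cyclopentyl in place of isobutyl on an amide-type nitrogen. For the measured compounds named here, no measured pair shows this change, so the expectation rests on its size alone. Swapping one small alkyl group for another of similar size on an amide nitrogen is usually a small matter, and I expect the step from compound 1 to compound 4 to be small, a 1.3-fold lower number from compound 1 to compound 4 (0.12 log units; within the scatter), not beyond the scatter. Compound 4 is therefore estimated at 3800 nM, with a likely range from 1300 nM to 11000 nM.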

Compound 4, concentration for 50% growth inhibition: 27400 nM
Beside the measured number, compound 4's estimate is 7.2-fold (0.86 log units) below it; measured number above the stated range.
By their numbers in this assay, from the lowest: compound 3; then compounds 2 and 1 (each within the scatter of the next); then compound 4.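

In this assay the alkyl group on the amide-type nitrogen turns out to matter: with the rest of compound 1 unchanged, cyclopentyl in place of isobutyl gives a 5.5-fold higher number from compound 1 to compound 4 (0.74 log units; beyond the scatter) and so clearly weakens inhibition of growth. The change looks slight on paper, with 4 heavy atoms leaving and 5 entering, all carbon, the main difference being an open branched group replaced by a closed ring, so a similar atom count does not guarantee a similar result at this position. Nothing available here accounts for this drop in activity, and this single pair is all that shows the change.

Going by these compounds, it remains open whether the ring itself or the extra carbon makes the difference; a straight pentyl chain or a smaller cyclopropyl ring on the same nitrogen would help separate the two. On these data alone, it also remains open whether this nitrogen accepts anything better than isobutyl, such as a chain ending in an amine or a carboxylic acid.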